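Methyl on the ring of compound 2

The source may report more compounds than this note shows. Statements on the series, on what has been measured and on what is new or still open speak of the compounds shown alone.

In an ADME assay on the whole organism (Rattus norvegicus, strain Sprague-Dawley) for pharmacokinetics, using cassette dosing, at a dose of 0.5 mg/kg by the intravenous route (on this read-out higher numbers stand for fast clearance and lower numbers for slow clearance), compound 1 (`O=C(Nc1ccc2[nH]c(=O)oc2c1)C(=O)N1CCN(c2ccc(C(F)(F)F)cc2)CC1`) gives 15.1 mL/min/kg. Compound 2 (`O=C(Nc1ccc2[nH]c(=O)oc2c1)C(=O)N1CCN(c2ccc(F)c(F)c2)CC1`) gives 4 mL/min/kg and compound 3 (`C[C@@H]1CN(c2ccc(F)c(F)c2)CCN1C(=O)C(=O)Nc1ccc2[nH]c(=O)oc2c1`) gives 5.6 mL/min/kg; these two lie within the scatter of each other, and both numbers sit well under that of compound 1. Compound 4 (`C[C@@H]1CN(C(=O)C(=O)Nc2ccc3[nH]c(=O)oc3c2)CCN1c1ccc(F)c(F)c1`) departs from compound 2 by one change: methyl in place of hydrogen on a saturated ring carbon. For the measured compounds named here, the closest precedent is the same swap on another carbon of that ring, a 1.4-fold higher number from compound 2 to compound 3 (0.15 log units; within the scatter). The other measured step, a 3.8-fold lower number from compound 1 to compound 2 (0.58 log units; beyond the scatter), changes the aryl group, which compound 4 keeps, so it bears little. No shift beyond the scatter is therefore expected in this assay. The expected change is a 1.4-fold higher number from compound 2 to compound 4 (0.14 log units; within the scatter). Compound 4 is estimated at 5.5 mL/min/kg, with an expected range of 2.5 mL/min/kg to 11 mL/min/kg.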

Compound 4, clearance: 15.9 mL/min/kg
Estimate against measurement, compound 4: 2.9-fold (0.46 log units) below; the whole stated range lies below it.
By their numbers in this assay, from the lowest: compounds 2 and 3 (each within the scatter of the next); then compounds 1 and 4 (each within the scatter of the next).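

In this assay, methyl in place of hydrogen on the saturated ring carbon next to the ring atom that bears a 3,4-difluorophenyl group gives a 4.0-fold higher number from compound 2 to compound 4 (0.60 log units; beyond the scatter), so this swap can move the read-out beyond the scatter. The same swap on another carbon of that ring gives a 1.4-fold higher number from compound 2 to compound 3 (0.15 log units; within the scatter), so in these compounds the size of the step depends on which ring carbon carries the methyl. Nothing shown here gives a reason for that difference. The compounds shown leave open whether an ethyl or a hydroxymethyl on this carbon would give a number like that of compound 4. They also leave open whether methyl in the opposite configuration at this carbon would do so.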